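Iodine in Place of Methyl on the Thiophene

The compounds below may be only part of what the source reports. "The series", "measured", "known", "first", "only" and "open" are said of these compounds alone.

Compound 1 `O=C(/C=C/c1ccc(N2CCCCC2)cc1)c1cccs1` is the parent of this pair. In an ADME assay on CCRF-CEM cells (Homo sapiens) for cytotoxicity, with a stated time of 5 days (a higher number here means a weaker inhibitor, a lower number a stronger inhibitor), compound 1 gives 11600 nM. Compound 2 `Cc1ccsc1C(=O)/C=C/c1ccc(N2CCCCC2)cc1` carries a methyl in place of hydrogen on an aromatic carbon, and in this assay compound 2 gives 9900 nM. The step of a 1.2-fold lower number from compound 1 to compound 2 (0.07 log units; within the scatter) is the only one measured, and the two numbers sit alongside each other without any separation that could be trusted.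

Compound 3 `O=C(/C=C/c1ccc(N2CCCCC2)cc1)c1ccc(I)s1` is not yet measured. Relative to compound 2 the change is 5-iodothiophen-2-yl in place of 3-methylthiophen-2-yl on a carbonyl carbon. Among the compounds with values here, the only measured step that bears on this change is the one from compound 1 to compound 2, which altered the same ring by adding a methyl and produced a 1.2-fold lower number from compound 1 to compound 2 (0.07 log units; within the scatter), a difference within the scatter. A change on the same ring by a single substituent is therefore expected to leave the number close to where compound 2 stands, with no step beyond the scatter in either direction. Compound 3 is estimated to give 8500 nM in this assay, within a range of 3000 nM to 25000 nM. That estimate corresponds to an expected step of a 1.2-fold lower number from compound 2 to compound 3 (0.07 log units; within the scatter).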

Compound 3, half-maximal inhibitory concentration: 22000 nM
Beside the measured number, compound 3's estimate is 2.6-fold (0.41 log units) below it; the measured number falls inside the stated range.
By their numbers in this assay, from the lowest: compounds 2, 1 and 3 (each within the scatter of the next, the first and the last beyond it).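

In this assay, 5-iodothiophen-2-yl in place of 3-methylthiophen-2-yl on the carbonyl carbon gives a 2.2-fold higher number from compound 2 to compound 3 (0.35 log units; beyond the scatter), a modest step but the first among these compounds to lie beyond the scatter, so a change confined to this ring can separate two compounds in this assay. Adding the iodo group to the unsubstituted ring gives a 1.9-fold higher number from compound 1 to compound 3 (0.28 log units; within the scatter), which stays within the scatter, so the iodo compound cannot be told apart from the parent and the separation appears only against the methyl compound. No measurement among the data accounts for this step.

The compounds shown tie each substituent to a single place, the methyl in 3-methylthiophen-2-yl and the iodo in 5-iodothiophen-2-yl, which leaves the effect of the group tangled with that of its place on the ring. As far as these compounds go, whether 5-methylthiophen-2-yl or 3-iodothiophen-2-yl would untangle the two remains open, as does whether a chloro group or an amine on the same ring would move the number beyond the scatter from the parent.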